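Compound 3: a new group on the shared core

A few compounds are considered here, and "the series" means these few. Any claim that something is new, unique, unknown or untested is made for them only; others in the source may bear on it.

- compound 1 `CC(C)CN1C(=O)/C(=C/c2ccc([N+](=O)[O-])cc2)S/C1=N\c1ccccc1`: > 100000 nM (a limit)
- compound 2 `Cc1ccsc1/C=C1\S/C(=N\c2ccccc2)N(CC(C)C)C1=O`: 89200 nM
- compound 3 `COc1cc(/C=C2\S/C(=N\c3ccccc3)N(CC(C)C)C2=O)ccc1O`: not yet measured

Within the data shown here, in an ADME assay on HepG2 cells (Homo sapiens) for cytotoxicity, read by MTT assay, with a stated time of 48 h (a lower number here means a stronger inhibitor, a higher number a weaker inhibitor), compound 2 gives 89200 nM, the only exact number so far. Compound 1 gives > 100000 nM, which is a limit of the assay. Compound 3 carries 4-hydroxy-3-methoxyphenyl in place of 3-methylthiophen-2-yl on a double-bonded chain carbon bound to a double-bonded ring carbon. Among the measured compounds shown here, only one measured step bears on this place: an at least 1.1-fold lower number from compound 1 to compound 2 (0.04 log units; that floor lies within the scatter). No step beyond the scatter is therefore expected in this assay, in either direction. The expected change is a 1.1-fold lower number from compound 2 to compound 3 (0.05 log units; within the scatter). For compound 3 the estimated value is 80000 nM, with an expected range of 35000 nM to 160000 nM.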

Compound 3, half-maximal inhibitory concentration in the HepG2 assay: 89500 nM
Beside the measured number, compound 3's estimate is 1.1-fold (0.05 log units) below it; the measured number falls inside the stated range.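

Among these compounds, in the HepG2 assay 4-hydroxy-3-methoxyphenyl in place of 3-methylthiophen-2-yl on a double-bonded chain carbon bound to a double-bonded ring carbon gives a 1.0-fold higher number from compound 2 to compound 3 (0.00 log units; within the scatter), so for the first time two exact numbers at this position cannot be told apart, despite a different aromatic ring and an added hydrogen-bond donor. In a physicochemical assay for lipophilicity, measured as octanol-water partition (on this read-out higher numbers stand for higher lipophilicity and lower numbers for lower lipophilicity), compound 2 gives 5.81 and compound 3 gives 4.92. The same change does separate the two compounds in the physicochemical assay: the measured partition coefficient of compound 2, 5.81, and of compound 3, 4.92, a number 0.89 log units lower (beyond the scatter) In the HepG2 assay compound 1 gives > 100000 nM, which is a limit of the assay. In the HepG2 assay the step from that limit is an at least 1.1-fold lower number from compound 1 to compound 3 (0.04 log units; that floor lies within the scatter), and it cannot be read.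

From the compounds shown here alone, whether an amine or a carboxylic acid at this position would give a clearly lower number in the HepG2 assay remains open.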